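Changing the Amine Ring of Compound 2

The source may report more compounds than this note shows. Statements on the series, on what has been measured and on what is new or still open speak of the compounds shown alone.

Of the compounds shown here, three built on one shared core have been tested in a functional assay on MDA-MB-231 cells (Homo sapiens) for inhibition, read by MTT assay, with stated times of 18 h and 4 h; a lower number here means a stronger inhibitor, a higher number a weaker inhibitor. Compound 1 `CCCCCCCCCCCCCCCCOP(=O)(O)OCCSC(=S)N1CCCCCC1` gives only a limit there, > 100000 nM, so no number exists for it. Compound 2 `CCCCCCCCCCOP(=O)(O)OCCSC(=S)N1CCCCCC1` gives 11400 nM, and compound 3 `CCCCCCCCOP(=O)(O)OCCSC(=S)N1CCCCC1` gives 11900 nM. Compound 2 thus holds the lowest of the two real numbers, yet its gap to compound 3 lies within the scatter, so the two cannot be told apart. Among the compounds with values here, the single measured step is an at least 8.7-fold lower number from compound 1 to compound 2 (0.94 log units; beyond the scatter), and it concerns the long chain, not the ring at the other end of the molecule. Within the data shown here, the unmeasured compound 4 `CCCCCCCCCCOP(=O)(O)OCCSC(=S)N1CCN(C)CC1` keeps the chain of compound 2 and alters only that ring: 4-methylpiperazin-1-yl in place of azepan-1-yl on a thiocarbonyl carbon. Among the measured compounds shown here, no measured step touches this part of the structure, so there is no basis for expecting a shift beyond the scatter in this assay. Compound 4 is therefore expected to give about 12000 nM, somewhere between 4000 nM and 40000 nM. This estimate means an expected step of a 1.1-fold higher number from compound 2 to compound 4 (0.02 log units; within the scatter).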

Compound 4, half-maximal inhibitory concentration: 29000 nM
For compound 4 the middle estimate is 2.4-fold (0.38 log units) below the measured one; low and high end bracket the measured number.
By their numbers in this assay, from the lowest: compounds 2 and 3 (each within the scatter of the next); then compound 4. At a limit, above all of these: compound 1.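

Within the data shown here, the amine ring on the thiocarbonyl carbon turns out to matter in this assay: the step is a 2.5-fold higher number from compound 2 to compound 4 (0.41 log units; beyond the scatter), whereas the only step available before concerned the long chain. The step is modest, and compound 4 still gives a real number rather than a limit. This one swap changes the ring size, adds a second ring nitrogen and adds a methyl group, and nothing shown explains the shift.

As far as these compounds go, it remains open whether a morpholin-4-yl or pyrrolidin-1-yl ring on the chain of compound 2 would give a number closer to that of compound 2 or that of compound 4. From the compounds shown here alone, it is also open whether 4-methylpiperazin-1-yl would move the number in the same way on a longer chain.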